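The source may hold more compounds than are shown below. What is called first, only, known or untested is meant among the compounds shown, and "the series" means these compounds.

Measured so far in a functional assay on HepG2 cells (Homo sapiens) for inhibition, read by MTT assay, with a stated time of 72 h; on this read-out higher numbers stand for weaker inhibition and lower numbers for stronger inhibition:
compound 1, `COc1cccc(-n2cc(COc3cccc(NC(=O)Nc4ccc(Cl)c(C(F)(F)F)c4)c3)nn2)c1`, 1310 nM
compound 2, `Cc1ccc(-n2cc(COc3cccc(NC(=O)Nc4ccc(Cl)c(C(F)(F)F)c4)c3)nn2)cc1`, 5430 nM
compound 3, `O=C(Nc1cccc(OCc2cn(-c3cccc(F)c3)nn2)c1)Nc1ccc(Cl)c(C(F)(F)F)c1`, 2120 nM

Compound 3 sits second highest of the three numbers in this assay. Its nearest neighbour is compound 1, with a 1.6-fold higher number from compound 1 to compound 3 (0.21 log units; within the scatter), a gap inside the scatter; the furthest is compound 2, with a 2.6-fold lower number from compound 2 to compound 3 (0.41 log units; beyond the scatter). The series so far varies only the aryl group on the triazole nitrogen, and the spread across it is modest: a 4.1-fold higher number from compound 1 to compound 2 (0.62 log units; beyond the scatter) is the largest step shown.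

Compound 4, `O=C(Nc1cccc(OCc2cn(-c3ccccc3Cl)nn2)c1)Nc1ccc(Cl)c(C(F)(F)F)c1`, continues this variation: 2-chlorophenyl in place of 3-fluorophenyl on an aromatic nitrogen. Among the measured compounds shown here, no measured step involves a 2-chlorophenyl or any other aryl with a substituent in that arrangement, so the bearing steps are indirect. The exchange of fluoro for methoxy on the aromatic carbon left the number essentially unchanged, and the move from 4-methylphenyl to 3-fluorophenyl gave only a modest shift. On that basis the step to compound 4 is expected to stay near compound 3, with no change beyond the scatter in this assay most likely, and a 1.2-fold higher number from compound 3 to compound 4 (0.07 log units; within the scatter) is the expected step. For compound 4 the estimated value in this assay is 2500 nM, with a range from 900 nM to 7000 nM.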

Compound 4, half-maximal inhibitory concentration: 1960 nM
The estimate for compound 4 lay 1.3-fold (0.11 log units) above the measured number, and the stated range covers the measured number.
By their numbers in this assay, from the lowest: compounds 1, 4 and 3 (each within the scatter of the next); then compound 2.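

In this assay, among the compounds shown here, the 2-chlorophenyl group on the aromatic nitrogen is the first aryl with its substituent in this arrangement and with chlorine as that substituent, and it gives a number indistinguishable from that of the 3-fluorophenyl group (a 1.1-fold lower number from compound 3 to compound 4 (0.03 log units; within the scatter)) and of the 3-methoxyphenyl group (a 1.5-fold higher number from compound 1 to compound 4 (0.17 log units; within the scatter)). The position therefore accepts three differently substituted phenyl groups with no separation beyond the scatter, while the 4-methylphenyl group remains the only one apart, now also from the 2-chlorophenyl group (a 2.8-fold lower number from compound 2 to compound 4 (0.44 log units; beyond the scatter)). The data give no explanation for either the close agreement among these three groups or the separation of the fourth.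

Still open, as far as these compounds go, is whether the gap belongs to the methyl group itself or to its arrangement on the ring, a question that a 4-chlorophenyl or 2-methylphenyl group on the same nitrogen would address. Also open, from the compounds shown here alone, is whether this flat response persists beyond neutral aryl groups, for example with an aminomethyl group or a carboxylic acid on the phenyl ring, or with a benzyl group in place of the phenyl.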